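Thioether series: from compound 3 to compound 4

A few compounds are considered here, and "the series" means these few. Any claim that something is new, unique, unknown or untested is made for them only; others in the source may bear on it.

Measured in a functional assay on PC-3 cells (Homo sapiens) for inhibition, read by MTT assay, with a stated time of 48 h; on this read-out higher numbers stand for weaker inhibition and lower numbers for stronger inhibition:
- compound 1 `COc1ccc(CSc2nnc(-c3cc(OC)c(OC)c(OC)c3)n2-c2ccc(OC)cc2)cc1`: 40300 nM
- compound 2 `CCOC(=O)CSc1nnc(-c2cc(OC)c(OC)c(OC)c2)n1-c1ccc(OC)cc1`: > 60000 nM (a limit)
- compound 3 `COc1ccc(CSc2nnc(-c3cc(OC)c(OC)c(OC)c3)n2-c2ccc(N(C)C)cc2)cc1`: > 60000 nM (a limit)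

Compound 3 stands at the limit of > 60000 nM in this assay, at which 2 of the 3 values shown sit. Compound 4 `COc1ccc(C(=O)CSc2nnc(-c3cc(OC)c(OC)c(OC)c3)n2-c2ccc(N(C)C)cc2)cc1O` carries (3-hydroxy-4-methoxyphenyl)carbonyl in place of 4-methoxyphenyl on a saturated chain carbon bound to a sulfur. The nearest step at that place is an at least 1.4-fold higher number from compound 1 to compound 2 (0.17 log units; that floor lies within the scatter), and the step on the other aryl group is an at least 1.4-fold higher number from compound 1 to compound 3 (0.17 log units; that floor lies within the scatter). Both rest on limits, so neither sets a size. Within the data shown here, compound 1 at 40300 nM is the only true number, and it anchors the expectation. An estimated at least 2.4-fold lower number from compound 3 to compound 4 (0.38 log units; beyond the scatter) is expected, towards stronger inhibition, with low confidence. Compound 4 is expected at 25000 nM, with an estimated range of 2000 nM to 60000 nM.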

Compound 4, half-maximal inhibitory concentration: > 100000 nM
Compound 4 gave a limit, no number (the forecaster's own chance of this, stated with the estimate: 35%); middle value at least 4.0-fold (0.60 log units) from the limit.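

Compound 3 gives only the limit > 60000 nM here. Among these compounds, compound 4 also gives only a limit, > 100000 nM and no step between compound 3 and compound 4 can be read. As far as these compounds go, whether (3-hydroxy-4-methoxyphenyl)carbonyl in place of 4-methoxyphenyl shifts inhibition at all, in either direction, stays open.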